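This account rests on a few compounds, and the source may have more. Where it says the series, first, only, none or still open, it means among the compounds named here.

Series notes on metabolic stability. Compound 1 `CCC(=O)N[C@@H]1CCCc2c1cncc2N1CCc2cc(Cl)ccc2C1=O` carries a propanoyl on the amine nitrogen of the saturated ring. In an ADME assay on microsomes from liver (Rattus norvegicus) for metabolic stability, read by LC-MS, using NADPH, with stated times of 10 min and 30 min (on this read-out higher numbers stand for fast clearance and lower numbers for slow clearance), compound 1 gives < 20.2 mL/min/kg, which is a limit of the assay and not a measured number. Its position on the numbers is therefore only a ceiling, as the limit of < 20.2 mL/min/kg in this assay, at which 1 of the 2 values shown sits, records. Going by the values given here, the other measured member, compound 2 `CC(=O)N1CC2(C1)CN(c1cncc(N3C(=O)c4ccc(Cl)cc4C3(C)C)c1)C2`, gives 3.71 mL/min/kg in this assay; it differs from compound 1 in more than one place, so no single step connects the two, and the pair shows only that both values fall on the slow-clearance side of the read-out.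

Compound 3 `CS(=O)(=O)N[C@@H]1CCCc2c1cncc2N1CCc2cc(Cl)ccc2C1=O` remains to be measured. It differs from compound 1 by methylsulfonyl in place of propanoyl on an amine nitrogen. Among the compounds with values here, no measured step covers this change, so the step expected here is a step that the limit leaves unreadable from compound 1 to compound 3, which is read as none beyond the usual scatter. Compound 3 is accordingly estimated at about 10 mL/min/kg in this assay, within a range from 3 mL/min/kg to 25 mL/min/kg, with a fair chance that only a limit is again reported.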

Compound 3, clearance: < 20.2 mL/min/kg
Compound 3 gave a limit, no number (the forecaster's own chance of this, stated with the estimate: 50%); the middle value is on the limit's open side.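

Compound 1 and compound 3 both return only a limit in this assay, not a number, so no step can be read between them: the limit of < 20.2 mL/min/kg in this assay, at which 2 of the 3 values shown sit.

The compounds shown leave open whether methylsulfonyl in place of propanoyl on an amine nitrogen changes clearance at all.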